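A few compounds are considered here, and "the series" means these few. Any claim that something is new, unique, unknown or untested is made for them only; others in the source may bear on it.

Measured compounds in a functional assay on MKN-45 cells (Homo sapiens) for cytotoxicity, read by MTT assay, with a stated time of 72 h; a higher number here means a weaker inhibitor, a lower number a stronger inhibitor:
Compound 1, `CN(C)CCCNc1nc(-c2ccc(NC(=O)Nc3ccc(F)cc3)cc2)nc2c(Cl)c(Cl)sc12`, gives 1120 nM.
Compound 2, `CN(C)CCCNc1nc(-c2ccc(NC(=O)Nc3ccccc3Cl)cc2)nc2c(Cl)c(Cl)sc12`, gives 1330 nM.
Compound 3, `CN(C)CCCNc1nc(-c2ccc(NC(=O)Nc3ccc(Cl)cc3Cl)cc2)nc2c(Cl)c(Cl)sc12`, gives 2560 nM.

Compound 2 stands second highest of the three numbers; its nearest neighbour is compound 1, with a 1.2-fold higher number from compound 1 to compound 2 (0.07 log units; within the scatter), and its furthest is compound 3, with a 1.9-fold higher number from compound 2 to compound 3 (0.28 log units; within the scatter). For the measured compounds named here, the only recorded step beyond the scatter is a 2.3-fold higher number from compound 1 to compound 3 (0.36 log units; beyond the scatter), and it too sits on the urea end of the shared core. All three measured steps alter the phenyl on an amide-type nitrogen: 2-chlorophenyl in place of 4-fluorophenyl, 2,4-dichlorophenyl in place of 4-fluorophenyl, and chloro in place of hydrogen on an aromatic carbon.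

Compound 4, `CCN(CC)CCCNc1nc(-c2ccc(NC(=O)Nc3ccccc3Cl)cc2)nc2c(Cl)c(Cl)sc12`, is not yet measured. It differs from compound 2 at the opposite end of the shared core: diethylamino in place of dimethylamino on a saturated chain carbon, three bonds along the chain from a nitrogen on an aromatic ring. The urea end is kept as 2-chlorophenyl, exactly as in compound 2. Going by the values given here, none of the measured steps touches the chain or its terminal amine, so there is no direct precedent for this change in this assay. With the amine end otherwise unexplored, the expectation is a step of no more than the scatter, in no set direction: no change at the digits printed from compound 2 to compound 4 (within the scatter) is expected. Compound 4 is therefore estimated at 1330 nM in this assay, with a range of 600 nM to 3000 nM.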

Compound 4, half-maximal inhibitory concentration: 1450 nM
The estimate for compound 4 lay 1.1-fold (0.04 log units) below the measured number; measured number inside the range.
By their numbers in this assay, from the lowest: compounds 1, 2, 4 and 3 (each within the scatter of the next, the first and the last beyond it).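

In this assay the terminal amine of the chain now has its first reading, and diethylamino in place of dimethylamino, on a saturated chain carbon, three bonds along the chain from a nitrogen on an aromatic ring, stays within the scatter (a 1.1-fold higher number from compound 2 to compound 4 (0.04 log units; within the scatter)). For the compounds shown here, for this one pair, with 5 heavy atoms entering where 3 leave, the amine end gives no step beyond the scatter, while the only such step remains on the urea end (a 2.3-fold higher number from compound 1 to compound 3 (0.36 log units; beyond the scatter)). Nothing at hand offers an explanation for this result.

Going by these compounds, this single pair carries the 2-chlorophenyl urea throughout, so whether the same change stays within the scatter alongside 4-fluorophenyl or 2,4-dichlorophenyl remains open. Also open, on these data alone, is how far the amine end can be altered before the number moves: a primary amine, a hydroxyl in place of the terminal amine, or a longer chain than the 3-(dimethylamino)propyl and 3-(diethylamino)propyl groups would each test that limit.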